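The compounds below may be only part of what the source reports. "The series", "measured", "known", "first", "only" and "open" are said of these compounds alone.

Measured compounds:
compound 1 `N#C[Se]c1ccc(NC(=O)Oc2ccc(F)cc2)cc1`: 29500 nM
compound 2 `CCCOC(=O)Nc1ccc([Se]C#N)cc1`: 9100 nM
compound 3 `O=C(Nc1ccc([Se][Se]c2ccc(NC(=O)Oc3ccccc3)cc2)cc1)Oc1ccccc1`: 9000 nM

In an ADME assay on 184B5 cells (Homo sapiens) for cytotoxicity, read by MTT assay, with a stated time of 72 h (a higher number here means a weaker inhibitor of growth, a lower number a stronger inhibitor of growth), compound 2 gives the second highest of the three numbers. Compound 3 sits nearest to it, within the scatter, so the two cannot be ordered; compound 1 gives the highest number, and its gap to compound 2 lies beyond the scatter. Compound 4 `CCCCCCOC(=O)Nc1ccc([Se]C#N)cc1` is the next compound to be measured. It differs from compound 2 by propyl in place of hydrogen on a saturated chain carbon, three bonds along the chain from an oxygen next to a carbonyl group. For the measured compounds named here, no pair of measured compounds shows a step of this kind, so there is no measured guide to its size. The step of a 1.4-fold lower number from compound 2 to compound 4 (0.15 log units; within the scatter) is expected to be small, toward a lower number, and within the scatter. Compound 4 is expected to give 6500 nM, between 2500 nM and 20000 nM.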

Compound 4, concentration for total growth inhibition: 20000 nM
The estimate for compound 4 lay 3.1-fold (0.49 log units) below the measured number; measured number inside the range.
By their numbers in this assay, from the lowest: compounds 3 and 2 (each within the scatter of the next); then compounds 4 and 1 (each within the scatter of the next).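

For the compounds shown here, putting propyl in place of hydrogen on a saturated chain carbon, three bonds along the chain from an oxygen next to a carbonyl group, gives a 2.2-fold higher number from compound 2 to compound 4 (0.34 log units; beyond the scatter) in this assay and is the first step at this position that can be read. It shows that this position responds to the change, modestly and toward a weaker inhibitor of growth. Nothing available explains this shift.

On these data alone, whether a butyl chain or a longer chain than hexyl would continue this trend remains open. So does the effect of an amine or a carboxylic acid at the end of the chain.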